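A few compounds are considered here, and "the series" means these few. Any claim that something is new, unique, unknown or untested is made for them only; others in the source may bear on it.

Measured compounds in a functional assay on the whole organism for antagonist activity, with Mus musculus as the target; a higher number here means that more compound is needed for the effect, a lower number that less compound is needed:

Compound 1, `CCOC(=O)N(C)C(C)C#CCn1ccnc1`. In this assay compound 1 gives only a limit, > 100 mg/kg.
Compound 2, `CCOC(=O)N(C)C(C)C#CCn1cncc1C`. In this assay compound 2 gives 30 mg/kg.
Compound 3, `CN(C)C(=O)N(C)CC#CCn1ccnc1`. In this assay compound 3 gives only a limit, > 100 mg/kg.

Within the data shown here, the one counted step among the measured compounds is methyl in place of hydrogen on an aromatic carbon, which gives an at least 3.3-fold lower number from compound 1 to compound 2 (0.52 log units; beyond the scatter). Since compound 1 stands at a limit, the true size of that step is bounded only from below.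

Compound 3 carries a different core from compound 1; the difference between the two cores is not broken down here.

The unmeasured compound 4, `Cc1cncn1CC#CCN(C)C(=O)N(C)C`, is compound 3 with the same change, (methyl in place of hydrogen on an aromatic carbon). For this assay the expected step is an at least 2.0-fold lower number from compound 3 to compound 4 (0.30 log units; that floor lies within the scatter), set beside an at least 3.3-fold lower number from compound 1 to compound 2 (0.52 log units; beyond the scatter) and resting on that pair alone. Because of the limit of > 100 mg/kg in this assay, at which 2 of the 3 values shown sit, compound 3 also gives only a bound, so the step from it can likewise only be bounded until compound 4 is measured. Compound 4 is expected to give about 50 mg/kg in this assay, between 15 mg/kg and 150 mg/kg.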

Compound 4, dose for half-maximal effect: > 100 mg/kg
Compound 4 gave a limit, no number (the forecaster's own chance of this, stated with the estimate: 40%); middle value at least 2.0-fold (0.30 log units) away from the limit.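

No new step can be read from compound 3 to compound 4 in this assay, because both compounds stand at a limit and not at a number: the limit of > 100 mg/kg in this assay, at which 3 of the 4 values shown sit.

The compounds shown leave open whether methyl in place of hydrogen on an aromatic carbon lowers the number on the core of compound 3, as it does on the core of compound 1.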